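The compounds below may be only part of what the source reports. "The series", "measured", "known", "first", "only" and "open" are said of these compounds alone.

Two compounds of the series carry numbers in an assay on cells for positive allosteric modulation of Cystic fibrosis transmembrane conductance regulator variant F508del (Homo sapiens), with stated times of 10 min and 7 s, in the presence of a further agent that is not named here; a higher number here means that more compound is needed for the effect, a lower number that less compound is needed. Compound 1 `Cc1ccc(C(=O)Nc2sc3c(c2C(N)=O)CCOC3)s1` gives 778 nM in this assay. Compound 2 `CC1(C)Cc2c(sc(NC(=O)c3nnc[nH]3)c2C(N)=O)C(C)(C)O1` gives 467 nM in this assay, the lower of the two numbers, though compound 1 sits within the scatter of compound 2, so the two values show no order. Compound 3 `CC1(C)Cc2c(sc(NC(=O)C3(O)CC3)c2C(N)=O)C(C)(C)O1` has not yet been measured. It differs from compound 2 in one place: 1-hydroxycyclopropyl in place of 4H-1,2,4-triazol-3-yl on a carbonyl carbon. Among the compounds with values here, no step between measured compounds bears on this change, so the expected step from compound 2 to compound 3 in this assay is a 1.5-fold higher number from compound 2 to compound 3 (0.18 log units; within the scatter), a small movement towards a higher number that may not exceed the scatter. The estimate for compound 3 in this assay is 700 nM, with a range from 200 nM to 2500 nM.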

Compound 3, half-maximal effective concentration: 23 nM
Estimate against measurement, compound 3: 30-fold (1.48 log units) above; measured number outside the range, below it.
By their numbers in this assay, from the lowest: compound 3; then compounds 2 and 1 (each within the scatter of the next).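

On the carbonyl carbon whose other neighbour is the amide-type nitrogen, 1-hydroxycyclopropyl in place of 4H-1,2,4-triazol-3-yl gives a 20-fold lower number from compound 2 to compound 3 (1.31 log units; beyond the scatter) in this assay. The result shows that this position strongly affects the number, which the two earlier values, within the scatter of each other, gave no sign of. No measurement at hand accounts for the size of this step.

As far as these compounds go, whether the step goes with the hydroxyl or with the three-membered ring remains open. A plain cyclopropyl or an open-chain tertiary alcohol on this carbonyl carbon would separate the two.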